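Shifting a methyl on the triazole aryl of compound 1

The source may report more compounds than this note shows. Statements on the series, on what has been measured and on what is new or still open speak of the compounds shown alone.

Measured compounds:
compound 1 `Cc1ccccc1-n1cc(CN2C(=O)C[C@@H]3CC[C@@]2(C)C3(C)C)nn1`: 80 nM
compound 2 `CC1(C)[C@H]2CC[C@]1(C)N(Cc1cn(-c3cccc(C#N)c3)nn1)C(=O)C2`: 320 nM
compound 3 `CC1(C)[C@H]2CC[C@]1(C)N(Cc1cn(-c3ccc(O)cc3)nn1)C(=O)C2`: 410 nM

In a functional assay on LoVo cells (Homo sapiens) for inhibition, read by MTT assay, with a stated time of 24 h (on this read-out higher numbers stand for weaker inhibition and lower numbers for stronger inhibition), compound 1 stands lowest of the three, with compound 2 nearest and compound 3 furthest; both other compounds lie beyond the scatter from it, so compound 1 is the strongest of the measured set on this read-out.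

Compound 4 `Cc1cccc(-n2cc(CN3C(=O)C[C@@H]4CC[C@@]3(C)C4(C)C)nn2)c1` differs from compound 1 only at the aryl on the triazole nitrogen: 3-methylphenyl in place of 2-methylphenyl on an aromatic nitrogen. The measured steps from this position are a 4.0-fold higher number from compound 1 to compound 2 (0.60 log units; beyond the scatter) and a 5.1-fold higher number from compound 1 to compound 3 (0.71 log units; beyond the scatter). Both replacements of the 2-methylphenyl gave a higher number of modest size, while the step of a 1.3-fold higher number from compound 2 to compound 3 (0.11 log units; within the scatter) stayed within the scatter. For the measured compounds named here, no measured step exchanges one methylphenyl for another, so the nearest guidance is that every departure from 2-methylphenyl seen so far has cost potency, though only modestly.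

The estimate for compound 4 is therefore a somewhat higher number than compound 1, with a step of about a 2.0-fold higher number from compound 1 to compound 4 (0.30 log units; within the scatter) expected. On this basis compound 4 is expected to give 160 nM, with a likely range from 60 nM to 450 nM.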

Compound 4, half-maximal inhibitory concentration: 50 nM
For compound 4 the middle estimate is 3.2-fold (0.51 log units) above the measured one; the whole stated range lies above it.
By their numbers in this assay, from the lowest: compounds 4 and 1 (each within the scatter of the next); then compounds 2 and 3 (each within the scatter of the next).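

Compound 4 is the first departure from 2-methylphenyl that does not move the number beyond the scatter: in this assay the change to 3-methylphenyl gives a 1.6-fold lower number from compound 1 to compound 4 (0.20 log units; within the scatter), so among the compounds shown the two placements of the methyl cannot be told apart. The earlier compounds shown here left open whether the loss lay with moving away from 2-methylphenyl as such, but the two methylphenyl compounds now stand together, apart from the nitrile and hydroxy compounds, with a 6.4-fold lower number from compound 2 to compound 4 (0.81 log units; beyond the scatter) for methyl in place of cyano and an 8.2-fold lower number from compound 3 to compound 4 (0.91 log units; beyond the scatter) for 3-methylphenyl in place of 4-hydroxyphenyl. Nothing available gives a reason for these differences.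

What the compounds shown leave open is how an amine, a carboxylic acid or an ethyl chain in place of the methyl would read on this aryl, so the reach of the methyl result beyond these four compounds remains unknown. They also leave open whether the closeness of compound 1 and compound 4 would hold in any cell line other than the one in this assay.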